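Trifluoromethyl for methoxy on the triazole aryl

The compounds below may be only part of what the source reports. "The series", "measured", "known", "first", "only" and "open" are said of these compounds alone.

Compound 2 `C=C1C[C@]23C[C@@]1(O)CC[C@H]2c1ccc(O)c(C)c1[C@@H]3Cn1cc(-c2ccc(OC)cc2)nn1` carries a free phenol and a 4-methoxyphenyl on the triazole. In a functional assay on MCF7 cells (Homo sapiens) for cytotoxicity, read by MTT assay, with a stated time of 4 days (a lower number here means a stronger inhibitor, a higher number a weaker inhibitor), compound 2 gives only a limit, > 20000 nM. Its tosylate partner compound 1 `C=C1C[C@]23C[C@@]1(O)CC[C@H]2c1ccc(OS(=O)(=O)c2ccc(C)cc2)c(C)c1[C@@H]3Cn1cc(-c2ccc(OC)cc2)nn1` gives the same kind of limit in this assay, > 20000 nM. The step from hydrogen in place of (4-methylphenyl)sulfonyl on an oxygen on an aromatic ring is therefore a step that the two limits leave unreadable from compound 1 to compound 2. Compound 3 `Cc1ccc(S(=O)(=O)Oc2ccc3c(c2C)[C@H](Cn2cc(-c4ccc(C(F)(F)F)cc4)nn2)[C@@]24CC(=O)[C@@](C)(CC[C@@H]32)C4)cc1`, which already bears a 4-(trifluoromethyl)phenyl on a different core, also stops at a limit in this assay, > 20000 nM.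

Compound 4 `C=C1C[C@]23C[C@@]1(O)CC[C@H]2c1ccc(O)c(C)c1[C@@H]3Cn1cc(-c2ccc(C(F)(F)F)cc2)nn1` differs from compound 2 by trifluoromethyl in place of methoxy on an aromatic carbon. Among the compounds with values here, no measured step covers this change; the only bearing evidence is the limit of > 20000 nM in this assay, at which 3 of the 3 values shown sit, so no step beyond the scatter can be read in either direction, and a further limit is the most likely outcome. The step expected in this assay is a step that the limit leaves unreadable from compound 2 to compound 4. Compound 4 is accordingly estimated at 25000 nM in this assay, within 10000 nM to 60000 nM.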

Compound 4, half-maximal inhibitory concentration: 12400 nM
Compound 4: the middle estimate sits 2.0-fold (0.30 log units) above what was measured; measured number inside the range.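

In this assay compound 4 gives 12400 nM, and it alone among the compounds shown has a readable number rather than a limit: the limit of > 20000 nM in this assay, at which 3 of the 4 values shown sit.

Trifluoromethyl in place of methoxy on the triazole aryl, with the free phenol and the shared core kept, gives an at least 1.6-fold lower number from compound 2 to compound 4 (0.20 log units; that floor lies within the scatter). That floor alone does not establish a real gain at this position, and the true size of the step stays unread, the value for compound 2 being only a limit.

The compounds shown leave open whether the free phenol matters once the 4-(trifluoromethyl)phenyl is present. They also leave open how a nitrile, a carboxylic acid or an amine on the same aromatic carbon would read in this assay.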